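Pyrrolidine to piperidine on the thiocarbonyl carbon

The source may report more compounds than this note shows. Statements on the series, on what has been measured and on what is new or still open speak of the compounds shown alone.

Compound 1 `O=c1c(SC(=S)N2CCCC2)coc2ccc(Cl)cc12` carries a pyrrolidin-1-yl group on a thiocarbonyl carbon. In a functional assay on MCF7 cells (Homo sapiens) for antiproliferative activity, read by MTT assay, with a stated time of 72 h (on this read-out lower numbers stand for stronger inhibition and higher numbers for weaker inhibition), compound 1 gives only a limit, > 25000 nM, and no number. Compound 2 `O=c1c(CSC(=S)N2CCN(c3ccccc3)CC2)coc2ccccc12` is the second member of the series. In this assay compound 2 likewise returns only a limit, > 30000 nM. The first limit is recorded as the limit of > 25000 nM in this assay, at which 1 of the 2 values shown sits. The second is recorded as the limit of > 30000 nM in this assay, at which 1 of the 2 values shown sits. Among the measured compounds shown here, compound 1 therefore has no numerical position among the measured compounds, only a limit, and no step between measured compounds can be computed.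

Compound 3 `O=c1c(SC(=S)N2CCCCC2)coc2ccc(Cl)cc12` has not been measured. It differs from compound 1 by piperidin-1-yl in place of pyrrolidin-1-yl on a thiocarbonyl carbon. Since compound 1 reports only a limit, > 25000 nM, in this assay, no step beyond the scatter is expected, and compound 3 is expected to remain at or near the limit. The step is expected to be a step that the limit leaves unreadable from compound 1 to compound 3. Compound 3 is estimated at 30000 nM, within 10000 nM to 100000 nM.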

Compound 3, half-maximal inhibitory concentration: > 25000 nM
Compound 3: no number, only a limit; the forecaster's own chance of this, stated with the estimate: 75%; the middle value lies beyond the limit too.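

In this assay compound 3 gives > 25000 nM, a limit and not a number. Compound 1 gives > 25000 nM, likewise a limit, so no step can be read between compound 1 and compound 3. The compounds shown leave open whether piperidin-1-yl and pyrrolidin-1-yl on a thiocarbonyl carbon differ at all in this assay.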